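From Acetylphenyl to a Methylindole

The source may hold more compounds than are shown below. What is called first, only, known or untested is meant among the compounds shown, and "the series" means these compounds.

In a functional assay on A549 cells (Homo sapiens) for inhibition, read by CCK-8 assay, with a stated time of 48 h (on this read-out lower numbers stand for stronger inhibition and higher numbers for weaker inhibition), compound 3 `COc1cc(-c2ccnc3cc(-c4ccc(C(C)=O)cc4)nn23)cc(OC)c1OC` gives 4100 nM, the highest number of the three measured compounds. Compound 1 `COc1cc(-c2ccnc3cc(-c4ccc5c(ccn5C)c4)nn23)cc(OC)c1OC` gives 15 nM, and compound 2 `COc1cc(-c2ccnc3cc(-c4ccc(N(C)C)cc4)nn23)cc(OC)c1OC` gives 1100 nM. Compound 4 `COc1cc(-c2ccnc3cc(-c4ccc5ccn(C)c5c4)nn23)cc(OC)c1OC` is unmeasured and carries 1-methyl-1H-indol-6-yl in place of 4-acetylphenyl on an aromatic carbon. Among the compounds with values here, the nearest precedent is the large 270-fold higher number from compound 1 to compound 3 (2.44 log units; beyond the scatter), read in reverse, since compound 1 carries 1-methyl-1H-indol-5-yl. The large 73-fold higher number from compound 1 to compound 2 (1.87 log units; beyond the scatter) points the same way, while a 3.7-fold higher number from compound 2 to compound 3 (0.57 log units; beyond the scatter) is modest. Within the data shown here, no measured compound shows how the 6-yl and 5-yl attachments compare, so a large drop is expected, probably short of the full reversal: a 68-fold lower number from compound 3 to compound 4 (1.83 log units; beyond the scatter). Compound 4 is estimated at 60 nM, with an expected range of 12 nM to 350 nM.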

Compound 4, half-maximal inhibitory concentration: 829 nM
Compound 4: the middle estimate sits 14-fold (1.14 log units) below what was measured; the whole stated range lies below it.
By their numbers in this assay, from the lowest: compound 1; then compounds 4 and 2 (each within the scatter of the next); then compound 3.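

In this assay the swap to 1-methyl-1H-indol-6-yl from 1-methyl-1H-indol-5-yl gives a 55-fold higher number from compound 1 to compound 4 (1.74 log units; beyond the scatter) and so shows that the attachment point of the indole matters at this position. Against 4-acetylphenyl the 6-yl indole brings only a 4.9-fold lower number from compound 3 to compound 4 (0.69 log units; beyond the scatter) and against 4-(dimethylamino)phenyl it brings a 1.3-fold lower number from compound 2 to compound 4 (0.12 log units; within the scatter) so it offers no clear gain over the latter group. As far as these compounds go, whether the 5-yl indole needs its methyl group, or whether a benzimidazole could replace it, stays open. Nothing at hand explains the gap between the two attachments.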